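Second chloro on the shared core: from a limit to a number

The source may hold more compounds than are shown below. What is called first, only, known or untested is meant among the compounds shown, and "the series" means these compounds.

Compound 1 `ClCc1cccc(Cn2cnc3ncnc(Cl)c32)c1`: > 100000 nM
Compound 2 `ClCc1ccccc1Cn1cnc2ncnc(Cl)c21`: > 100000 nM
Compound 3 `ClCc1cccc(Cn2cnc3nc(Cl)nc(Cl)c32)c1`: 1650 nM

In a functional assay on COLO 205 cells (Homo sapiens) for cytotoxicity, read by sulforhodamine B assay, with a stated time of 48 h (a higher number here means a weaker inhibitor of growth, a lower number a stronger inhibitor of growth), compound 1 gives > 100000 nM, which is a limit of the assay and not a number. Compound 2 likewise gives only a limit in this assay, > 100000 nM. Compound 2 has the same atoms as compound 1, joined differently; the difference between the two cores is not broken down here. Compound 3 is measured at 1650 nM in this assay.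

The change from compound 1 to compound 3 is chloro in place of hydrogen on an aromatic carbon, and it made the step of an at least 60-fold lower number from compound 1 to compound 3 (1.78 log units; beyond the scatter). The lower end of that step is set by the limit of > 100000 nM in this assay, at which 2 of the 3 values shown sit.

Compound 4 `ClCc1ccccc1Cn1cnc2nc(Cl)nc(Cl)c21` is not yet measured. It differs from compound 2 by chloro in place of hydrogen on an aromatic carbon, the same kind of change as from compound 1 to compound 3. Since compound 2 sits at the same limit as compound 1, the step is expected to be at least as large as the measured one, estimated as an at least 33-fold lower number from compound 2 to compound 4 (1.52 log units; beyond the scatter), resting on an at least 60-fold lower number from compound 1 to compound 3 (1.78 log units; beyond the scatter). Compound 4 is therefore expected to give about 3000 nM, between 700 nM and 30000 nM.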

Compound 4, concentration for total growth inhibition: > 100000 nM
Compound 4: a limit, no number; the forecaster's own chance of this, stated with the estimate: 15%; middle value at least 33-fold (1.52 log units) away from the limit.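

In this assay compound 4 gives > 100000 nM, which is a limit of the assay and not a number. Compound 2 also stands only at a limit, so no step can be read from compound 2 to compound 4: the limit of > 100000 nM in this assay, at which 3 of the 4 values shown sit.

The compounds shown leave open whether the second chloro changes growth inhibition at all on the core of compound 2.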